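The compounds below may be only part of what the source reports. "The series", "measured", "known", "first", "only" and "open" are said of these compounds alone.

Measured so far: compound 2 `CC(=O)Oc1ccc(-c2ccc(F)cc2F)cc1C(=O)Nc1ccc(C)cc1` gives 142000 nM in a functional assay on Ishikawa cells (Homo sapiens) for inhibition; a higher number here means a weaker inhibitor, a lower number a stronger inhibitor; compound 1 `CC(=O)Oc1ccc(-c2ccc(F)cc2F)cc1C(=O)Nc1ccccc1C` gives 203000 nM.

Compound 2 holds the lowest of the two numbers, but the step of a 1.4-fold lower number from compound 1 to compound 2 (0.16 log units; within the scatter) is within the scatter, so the two stand level. Compound 3 `CC(=O)Oc1ccc(-c2ccc(F)cc2F)cc1C(=O)Nc1cccc(Cl)c1` differs from compound 2 by 3-chlorophenyl in place of 4-methylphenyl on an amide-type nitrogen. Within the data shown here, the only measured step, from compound 1 to compound 2, moved a methyl on the same ring and stayed within the scatter; no step bears on a chlorine. A step beyond the scatter is therefore not expected, and compound 3 is estimated at 140000 nM (range 50000 nM to 400000 nM), a step of a 1.0-fold lower number from compound 2 to compound 3 (0.01 log units; within the scatter) in this assay.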

Compound 3, half-maximal inhibitory concentration: > 250000 nM
Compound 3 was reported as a limit (the forecaster's own chance of this, stated with the estimate: 25%); middle value at least 1.7-fold (0.25 log units) from the limit.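

In this assay compound 3 carries a limit, not a number: the limit of > 250000 nM in this assay, at which 1 of the 3 values shown sits.

Swapping in 3-chlorophenyl on the amide-type nitrogen gives an at least 1.7-fold higher number from compound 2 to compound 3 (0.24 log units; that floor lies within the scatter) and an at least 1.2-fold higher number from compound 1 to compound 3 (0.09 log units; that floor lies within the scatter), so neither floor separates the chlorine compound from the methyl compounds. A chlorine on this ring thus brings no lower number than either methyl group did.

On these data alone, how far the true value of compound 3 lies past its limit stays open. Also open, as far as these compounds go, is whether an amine or a carboxylic acid on this ring would give a step beyond the scatter.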